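The compounds below may be only part of what the source reports. "The series", "measured", "known", "first", "only" and "open" are said of these compounds alone.

Compound 1 `Oc1cccc(-c2cc(-c3cccs3)cc(-c3cccc(O)c3)n2)c1` carries a thiophen-2-yl group and two 3-hydroxyphenyl groups on the shared core. In an assay on isolated protein for inhibition of DNA topoisomerase 1 (Homo sapiens), with a stated time of 30 min, tested at 100 uM (on this read-out lower numbers stand for a weaker effect and higher numbers for a stronger effect at the one concentration tested), compound 1 gives 91.7%. Compound 2 `Oc1ccc(-c2cc(-c3cccs3)cc(-c3cccc(O)c3)n2)cc1` differs from compound 1 by 4-hydroxyphenyl in place of 3-hydroxyphenyl on an aromatic carbon; in this assay compound 2 gives 85.7%, the change making a number 6 percentage points lower from compound 1 to compound 2 (within the scatter). Compound 3 `Oc1cccc(-c2cc(-c3ccco3)cc(-c3cccc(O)c3)n2)c1` differs from compound 1 by furan-2-yl in place of thiophen-2-yl on an aromatic carbon; in this assay compound 3 gives 97.8%, the step being a number 6.1 percentage points higher from compound 1 to compound 3 (within the scatter). Compound 3 holds the highest of the three numbers; its gap to compound 1 is within the scatter, while its gap to compound 2 lies beyond it, so compound 3 stands above compound 2.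

Compound 4 `Oc1ccc(-c2cc(-c3ccco3)cc(-c3cccc(O)c3)n2)cc1` is not yet measured; it differs from compound 3 by 4-hydroxyphenyl in place of 3-hydroxyphenyl on an aromatic carbon. This is the same kind of change as from compound 1 to compound 2, the place now being meta to a furan-2-yl group rather than meta to a thiophen-2-yl group; the two cores differ by furan-2-yl in place of thiophen-2-yl on an aromatic carbon. Set beside the earlier step of a number 6 percentage points lower from compound 1 to compound 2 (within the scatter), the step from compound 3 to compound 4 in this assay is expected to be a number 5.8 percentage points lower from compound 3 to compound 4 (within the scatter), resting on that single earlier occurrence of the change and on the high starting value of compound 3. Compound 4 is therefore estimated at 92%, between 84% and 98%.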

Compound 4, a percentage reported as inhibition, at one concentration (the size of the read-out at that concentration, not a potency): 100%
Estimate against measurement, compound 4: 8 percentage points below; the measured number lies above the stated range.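

In this assay, 4-hydroxyphenyl in place of 3-hydroxyphenyl gives a number 2.2 percentage points higher from compound 3 to compound 4 (within the scatter), and the two occurrences of this change do not differ: the same change on two cores in this assay, a number 6 percentage points lower (within the scatter) from compound 1 to compound 2 and a number 2.2 percentage points higher (within the scatter) from compound 3 to compound 4, 8.2 percentage points apart, within the scatter of two such steps. Furan-2-yl in place of thiophen-2-yl gives a number 14.3 percentage points higher from compound 2 to compound 4 (beyond the scatter), and this step also agrees with its earlier occurrence: the same change on two cores in this assay, a number 6.1 percentage points higher (within the scatter) from compound 1 to compound 3 and a number 14.3 percentage points higher (beyond the scatter) from compound 2 to compound 4, 8.2 percentage points apart, within the scatter of two such steps. Each change therefore carries across the two cores shown without a difference that can be told from the scatter, but this rests on two occurrences per change, at one concentration, and does not show that the steps are equal or that they would hold on any other core.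

The compounds shown leave open what an amine or a carboxylic acid in place of the hydroxyl would give, and what a pyridin-2-yl group would give in place of furan-2-yl. Also open, going by these compounds, is how the effects of compound 3 and compound 4 would compare at any other concentration: the read-out here gives only the size of the effect at a single concentration.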